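This account rests on a few compounds, and the source may have more. Where it says the series, first, only, none or still open, it means among the compounds named here.

Measured so far: compound 1 `O=C(/C=C/c1ccc2c(c1)B(O)OC2)c1ccc(-c2ccccc2)cc1`, which in a functional assay on SK-OV-3 cells (Homo sapiens) for cytotoxicity, read by MTT assay, with a stated time of 48 h (a lower number here means a stronger inhibitor, a higher number a weaker inhibitor), gives 4900 nM; compound 2 `O=C(/C=C/c1ccc2c(c1)B(O)OC2)c1ccc(Cl)cc1`, which in this assay gives 3700 nM; compound 3 `O=C(/C=C/c1ccc2c(c1)B(O)OC2)c1ccc(Br)cc1`, which in this assay gives 4500 nM.

Compound 3 stands second highest of the three numbers, but both its neighbours lie within the scatter of it: a 1.1-fold lower number from compound 1 to compound 3 (0.04 log units; within the scatter) and a 1.2-fold higher number from compound 2 to compound 3 (0.09 log units; within the scatter). Compound 4 `O=C(/C=C/c1ccc2c(c1)B(O)OC2)c1ccc(I)cc1` differs from compound 3 by iodo in place of bromo on an aromatic carbon. Going by the values given here, the one step that bears on it most closely is the halogen exchange a 1.2-fold higher number from compound 2 to compound 3 (0.09 log units; within the scatter), with a 1.3-fold lower number from compound 1 to compound 2 (0.12 log units; within the scatter) and a 1.1-fold lower number from compound 1 to compound 3 (0.04 log units; within the scatter) alongside, all within the scatter. No step beyond the scatter is therefore expected in this assay for compound 4, in either direction: no change at the digits printed from compound 3 to compound 4 (within the scatter). Compound 4 is estimated at 4500 nM, with a range from 2500 nM to 8000 nM.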

Compound 4, half-maximal inhibitory concentration: 4200 nM
Compound 4: middle estimate off by 1.1-fold (0.03 log units), on the high side; the measured number falls inside the stated range.
By their numbers in this assay, from the lowest: compounds 2, 4, 3 and 1 (each within the scatter of the next).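

In this assay the iodo group on this aromatic carbon gives a 1.1-fold lower number from compound 3 to compound 4 (0.03 log units; within the scatter) and a 1.1-fold higher number from compound 2 to compound 4 (0.06 log units; within the scatter) and also a 1.2-fold lower number from compound 1 to compound 4 (0.07 log units; within the scatter) as the remaining step. Phenyl, chloro, bromo and iodo at this place, para to a large group, thus all lie within the scatter of one another, and the series of halogens now reaches iodo without a step beyond it. No measurement shown accounts for this flat result.

As far as these compounds go, whether an amine, a carboxylic acid or a methoxy group at this place would give a step beyond the scatter remains open. So does whether a change elsewhere in the shared core would do so.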